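A few compounds are considered here, and "the series" means these few. Any claim that something is new, unique, unknown or untested is made for them only; others in the source may bear on it.

Measured so far in a functional assay on MDA-MB-231 cells (Homo sapiens) for antiproliferative activity, read by MTT assay, with a stated time of 72 h; a higher number here means a weaker inhibitor, a lower number a stronger inhibitor:
- compound 1 `Cc1cc(C)cc(OCCCON2C(N)=NC(N)=NC23CCOCC3)c1`: 3570 nM
- compound 2 `NC1=NC2(CCSCC2)N(OCCCOc2ccccc2Br)C(N)=N1`: 10 nM
- compound 3 `NC1=NC2(CCSCC2)N(OCCCOc2ccccc2Cl)C(N)=N1`: 80 nM

Compound 1 holds the highest of these three numbers. Compound 4 `NC1=NC2(CCOCC2)N(OCCCOc2cccc(Cl)c2)C(N)=N1` is not yet measured. The change to it is 3-chlorophenyl in place of 3,5-dimethylphenyl on an oxygen on a saturated carbon. Going by the values given here, no measured step makes this swap. The nearest guide is an 8.0-fold higher number from compound 2 to compound 3 (0.90 log units; beyond the scatter), a modest step for chloro in place of bromo on an aromatic carbon, so it indicates size only. Compound 3 also carries chloro on an aromatic carbon, with a different core, and gives 80 nM. A modest step toward a lower number is therefore expected in this assay. The expected step is a 5.1-fold lower number from compound 1 to compound 4 (0.71 log units; beyond the scatter). For compound 4 the estimate is 700 nM, with an expected range of 150 nM to 3500 nM.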

Compound 4, half-maximal inhibitory concentration: 1020 nM
Compound 4: the middle estimate sits 1.5-fold (0.16 log units) below what was measured, within the range that was stated.
By their numbers in this assay, from the lowest: compound 2; then compound 3; then compound 4; then compound 1.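

With the core of compound 1 held fixed in this assay, 3-chlorophenyl in place of 3,5-dimethylphenyl on an oxygen on a saturated carbon gives a 3.5-fold lower number from compound 1 to compound 4 (0.54 log units; beyond the scatter). This is the only step shown on this core and shows that the number responds to the aromatic group here; the step between compound 2 and compound 3 belongs to a different core. Nothing on hand explains the size or direction of this step. Open, on these data alone, is whether the chloro or the loss of the methyl groups carries the step, since the swap changes both. Also open, as far as these compounds go, is how a methoxy group on the same ring would compare.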